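The source may report more compounds than this note shows. Statements on the series, on what has been measured and on what is new or still open speak of the compounds shown alone.

In a physicochemical assay for solubility, with a stated time of 18 h, at pH 7.4 (on this read-out lower numbers stand for lower solubility and higher numbers for higher solubility), the measured compounds read:
compound 1 `COc1ccc(F)cc1CNCCCNc1ccnc2cc(CCC(C)C)ccc12`: 4200 nM
compound 2 `COc1cccc(Oc2ccc3c(NCCCNCc4cc(F)ccc4OC)ccnc3c2)c1`: 14500 nM
compound 3 `COc1ccc(F)cc1CNCCCNc1ccnc2cc(CCc3ccccc3)ccc12`: 4200 nM

Compound 3 stands level with compound 1, together the lowest of the three numbers; compound 2 sits furthest from it, a 3.5-fold lower number from compound 2 to compound 3 (0.54 log units; beyond the scatter). Compound 4 `COc1ccc(F)cc1CNCCCNc1ccnc2cc(Cc3ccc(F)cc3Cl)ccc12` differs from compound 3 in one place: 2-chloro-4-fluorophenyl in place of benzyl on a saturated chain carbon bound to an aromatic carbon. Of the measured steps, only no change at the digits printed from compound 1 to compound 3 (within the scatter) touches the same chain carbon, and that step stayed within the scatter; the larger shifts, a 3.5-fold higher number from compound 1 to compound 2 (0.54 log units; beyond the scatter) and a 3.5-fold lower number from compound 2 to compound 3 (0.54 log units; beyond the scatter), concern a different place and bear only loosely. For the measured compounds named here, no measured step adds halogens to a ring there. The expectation for compound 4 is therefore a step of a 1.3-fold lower number from compound 3 to compound 4 (0.10 log units; within the scatter), within the scatter. Compound 4 is estimated at 3300 nM, between 1400 nM and 8000 nM.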

Compound 4, solubility: 4200 nM
Compound 4: the middle estimate sits 1.3-fold (0.10 log units) below what was measured; measured number inside the range.
By their numbers in this assay, from the lowest: compounds 1, 3 and 4 (each within the scatter of the next); then compound 2.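

In this assay, 2-chloro-4-fluorophenyl in place of benzyl on a saturated chain carbon bound to an aromatic carbon gives no change at the digits printed from compound 3 to compound 4 (within the scatter) and, in place of isobutyl at the same carbon, gives no change at the digits printed from compound 1 to compound 4 (within the scatter) so a ring bearing two halogens here reads like both earlier groups. Against 3-methoxyphenoxy on the aromatic carbon, 2-chloro-4-fluorobenzyl gives a 3.5-fold lower number from compound 2 to compound 4 (0.54 log units; beyond the scatter) so the halogenated ring does not close that gap. No evidence at hand explains these readings.

As far as these compounds go, whether an amine or a carboxylic acid on this chain carbon would shift the number remains open. So does whether an unsubstituted phenoxy would read like 3-methoxyphenoxy.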